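Thiocarboxamide series: N-substituent swap on the shared core

This account rests on a few compounds, and the source may have more. Where it says the series, first, only, none or still open, it means among the compounds named here.

Compound 1 `NC(=O)c1cn(Cc2ccccc2)c2ncnc(N)c12` carries a benzyl on the ring nitrogen and an amide; in a functional assay on KB cells (Homo sapiens) for cytotoxicity (on this read-out higher numbers stand for weaker inhibition and lower numbers for stronger inhibition), compound 1 gives 75000 nM. Within the data shown here, compound 2 `C=CCn1cc(C(N)=S)c2c(N)ncnc21` carries the allyl and the thiocarboxamide; in this assay compound 2 gives 19000 nM, the lower of the two plain numbers measured so far, with compound 1 sitting at the higher number and that gap beyond the scatter. Compound 3 `Cc1ccccc1Cn1cc(C#N)c2c(N)ncnc21` with its nitrile and 2-methylbenzyl reaches only a limit of the assay, > 100000 nM, with no number behind it; the series shows (the limit of > 100000 nM in this assay, at which 1 of the 3 values shown sits).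

Compound 4 `COCCOCn1cc(C(N)=S)c2c(N)ncnc21` keeps the thiocarboxamide of compound 2 and changes only the substituent on the ring nitrogen: 2-methoxyethoxy in place of vinyl on a saturated chain carbon bound to an aromatic nitrogen. Among the measured compounds shown here, the chain becomes longer and gains acceptors, but nothing in the measured set tests such a change, as no two measured compounds differ in one place. The expectation is therefore a step of modest size, if any, in this assay, leaning toward a somewhat higher number but not clearly beyond the scatter: from compound 2 to compound 4 the expected step is a 1.6-fold higher number from compound 2 to compound 4 (0.20 log units; within the scatter). Compound 4 is thus estimated at 30000 nM in this assay, in a range from 8000 nM to 100000 nM.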

Compound 4, half-maximal inhibitory concentration: 183000 nM
Compound 4: the middle estimate sits 6.1-fold (0.79 log units) below what was measured; measured number above the stated range.
By their numbers in this assay, from the lowest: compound 2; then compound 1; then compound 4.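

Among these compounds, the substituent on a saturated chain carbon bound to an aromatic nitrogen now gives the first one-place comparison: with the thiocarboxamide and the shared core held, (2-methoxyethoxy)methyl in place of allyl gives a 9.6-fold higher number from compound 2 to compound 4 (0.98 log units; beyond the scatter) in this assay. This place on the molecule is therefore not indifferent to the group it carries, and this change runs toward weaker inhibition by more than the usual scatter. Compound 3 stays outside this comparison, differing from compound 2 in more than one place, and its entry is a limit of the assay: the limit of > 100000 nM in this assay, at which 1 of the 4 values shown sits.

Among the compounds shown here, the single step does not separate the longer chain from the hydrogen-bond acceptors that enter with it, so an all-carbon chain such as pentyl, or a chain ending in an amine, in the same place would be the informative contrast. Also open, as far as these compounds go, is whether the same swap gives a step of similar size with the amide of compound 1 or the nitrile of compound 3 in place of the thiocarboxamide.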